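The source may hold more compounds than are shown below. What is called first, only, known or untested is meant among the compounds shown, and "the series" means these compounds.

In an ADME assay on Caco-2 cells (Homo sapiens) for permeability, in the apical to basolateral direction, at pH 7.4 (a lower number here means that the compound crosses the layer more slowly, a higher number that the compound crosses the layer faster), compound 2 `CN(C(=O)[C@H]1CN(S(=O)(=O)c2ccccc2)C[C@@H]1NC(=O)c1cc(-c2ccccc2Cl)on1)[C@H]1CCCNC1` gives 0.11 10^-6 cm/s, within the scatter of both compound 1 `Cc1oc(-c2ccc(Cl)cc2)nc1C(=O)N[C@H]1CN(S(=O)(=O)c2ccccc2)C[C@@H]1C(=O)N[C@H]1CCCNC1`, at 0.14 10^-6 cm/s, and compound 3 `CN(C(=O)[C@H]1CN(S(=O)(=O)c2ccccc2)C[C@@H]1N(C)C(=O)c1cc(-c2ccccc2Cl)on1)[C@H]1CCCNC1`, at 0.075 10^-6 cm/s. Compound 4 `CC(=O)N1CCC[C@H](NC(=O)[C@H]2CN(S(=O)(=O)c3ccccc3)C[C@@H]2NC(=O)c2cc(-c3ccccc3Cl)on2)C1` differs from compound 2 by this change: a group of 10 heavy atoms (7 carbon, 2 nitrogen, 1 oxygen; one six-membered non-aromatic ring with 1 hetero atom) in place of a group of 8 heavy atoms (6 carbon, 2 nitrogen; one six-membered non-aromatic ring with 1 hetero atom), on a carbonyl carbon. Among the compounds with values here, the only measured step that bears on it, with methyl in place of hydrogen on an amide-type nitrogen, is a 1.5-fold lower number from compound 2 to compound 3 (0.17 log units; within the scatter), and it stays within the scatter. Within the data shown here, no measured compound carries the entering group of 10 heavy atoms, so any expectation here is a cautious judgement. The expected change, upward and uncertain, is a 5.5-fold higher number from compound 2 to compound 4 (0.74 log units; beyond the scatter). For compound 4 the estimated value is 0.6 10^-6 cm/s, with an expected range of 0.15 10^-6 cm/s to 2.5 10^-6 cm/s.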

Compound 4, apparent permeability: 0.75 10^-6 cm/s
The estimate for compound 4 lay 1.3-fold (0.10 log units) below the measured number; measured number inside the range.
By their numbers in this assay, from the lowest: compounds 3, 2 and 1 (each within the scatter of the next); then compound 4.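

In this assay, this change on the carbonyl carbon gives the first step shown that lies beyond the scatter: a 6.8-fold higher number from compound 2 to compound 4 (0.83 log units; beyond the scatter). The two groups match in their counts of hydrogen-bond donors and acceptors and neither carries a net charge, so these counts do not separate them, while the entering group has 10 heavy atoms against 8, an oxygen and a double bond outside aromatic rings. No measurement here explains the rise. As far as these compounds go, whether a longer chain ending in a carboxylic acid or an amine at this carbonyl carbon would give a step of similar size stays open.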